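From an Isopropylcarbonyloxy Group to Fluoro

A few compounds are considered here, and "the series" means these few. Any claim that something is new, unique, unknown or untested is made for them only; others in the source may bear on it.

Measured so far:
compound 1 `COc1cccc2c(=O)cc(/C=C/[S+](C)[O-])oc12`: 9000 nM
compound 2 `CC(C)C(=O)Oc1ccc2oc(/C=C/[S+](C)[O-])cc(=O)c2c1`: 9100 nM

In a functional assay on DLD-1 cells (Homo sapiens) for cytotoxicity, with a stated time of 48 h (on this read-out lower numbers stand for stronger inhibition and higher numbers for weaker inhibition), compound 2 gives 9100 nM. Compound 1 gives 9000 nM, and the two lie within the scatter of each other, so neither stands apart. Compound 3 `C[S+]([O-])/C=C/c1cc(=O)c2cc(F)ccc2o1` has not yet been measured. It differs from compound 2 in one place: fluoro in place of (isopropylcarbonyl)oxy on an aromatic carbon. For the measured compounds named here, no measured pair shows a change of this kind, so its effect is unknown, and in this assay no step beyond the scatter is expected in either direction. Compound 3 is therefore estimated at 9000 nM, within a range from 3000 nM to 27000 nM, which as a step means a 1.0-fold lower number from compound 2 to compound 3 (0.00 log units; within the scatter).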

Compound 3, half-maximal inhibitory concentration: 7000 nM
The estimate for compound 3 lay 1.3-fold (0.11 log units) above the measured number; the measured number falls inside the stated range.
By their numbers in this assay, from the lowest: compounds 3, 1 and 2 (each within the scatter of the next).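

In this assay, fluoro in place of (isopropylcarbonyl)oxy on this aromatic carbon gives a 1.3-fold lower number from compound 2 to compound 3 (0.11 log units; within the scatter). At this position, then, replacing a group of 6 heavy atoms with a single fluorine atom, and losing 2 hydrogen-bond acceptors, produces no change beyond the scatter. No supporting measurement explains why the two groups read alike. Going by these compounds, whether an amine or a carboxylic acid on this carbon would move the number beyond the scatter remains open. So does the effect of a longer chain there.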